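Acetyl to propanoyl: from compound 1 to compound 4

The source may hold more compounds than are shown below. What is called first, only, known or untested is meant among the compounds shown, and "the series" means these compounds.

Compound 1 `CC(=O)N[C@H]1CC[C@H](NS(=O)(=O)c2ccc(F)cc2)CC1` gives 10 mg/kg in a functional assay on the whole organism with Mus musculus as the target, with a stated time of 20 min (a higher number here means that more compound is needed for the effect, a lower number that less compound is needed), the highest number among the three measured compounds. Its mirror image, compound 2 `CC(=O)N[C@H]1CC[C@@H](NS(=O)(=O)c2ccc(F)cc2)CC1`, gives 1 mg/kg, and the step of a 10-fold lower number from compound 1 to compound 2 (1.00 log units; beyond the scatter) rests on (the fact that compounds 1 and 2 differ only in the configuration as drawn). Compound 3 `CC(C)S(=O)(=O)Nc1ccc(N(C)S(=O)(=O)c2ccc(F)cc2)cc1`, built differently in several places, gives 0.1 mg/kg and stands furthest from compound 1 in this assay .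

Compound 4 `CCC(=O)N[C@H]1CC[C@H](NS(=O)(=O)c2ccc(F)cc2)CC1` differs from compound 1 by methyl in place of hydrogen on a saturated chain carbon bound to a carbonyl carbon, acetamido becoming propanoylamino. Within the data shown here, none of the measured steps bears on a change of this kind: a 10-fold lower number from compound 1 to compound 2 (1.00 log units; beyond the scatter) concerns configuration alone, and compound 3 is separated from compound 1 by more than one alteration, so no single step can be read from that pair. With nothing in the measured compounds to place the longer chain on either side, the expectation is a step of no change at the digits printed from compound 1 to compound 4 (within the scatter) that does not go beyond the scatter. Compound 4 is therefore estimated to give 10 mg/kg in this assay , with a range from 3 mg/kg to 30 mg/kg.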

Compound 4, minimum effective dose: 1 mg/kg
Compound 4: the middle estimate sits 10-fold (1.00 log units) above what was measured; the whole stated range lies above it.
By their numbers in this assay, from the lowest: compound 3; then compounds 2 and 4 (each within the scatter of the next); then compound 1.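

The change from acetamido to propanoylamino is a single added methyl, and in this assay it is enough to move the result: a 10-fold lower number from compound 1 to compound 4 (1.00 log units; beyond the scatter). The earlier step in this series concerned configuration alone, so this is the only measured sign that the acyl chain itself matters, and its size equals that of the other step, a 10-fold lower number from compound 1 to compound 2 (1.00 log units; beyond the scatter). Nothing available on these compounds accounts for the step from the added methyl.

On these data alone, whether the trend extends to a longer chain such as butanoyl, or to a branched chain such as isobutanoyl, remains open, as does the effect of an amine or a carboxylic acid at the end of that chain. As far as these compounds go, it is also open whether propanoylamino and the configuration of compound 2 would add up when combined in one compound.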